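This account rests on a few compounds, and the source may have more. Where it says the series, first, only, none or still open, it means among the compounds named here.

Compound 1 `O=C(Nc1ccc(Nc2ncnc3c2OCCN3)cc1)Nc1ccc(Cl)c(C(F)(F)F)c1`: > 10000 nM
Compound 2 `O=C(Nc1ccc(Br)cc1)Nc1ccc(Nc2ncnc3c2OCCN3)cc1`: 10000 nM
Compound 3 `COc1cccc(NC(=O)Nc2ccc(Nc3ncnc4c3OCCN4)cc2)c1`: > 10000 nM

These values come from a functional assay on BaF3 cells (Mus musculus) for inhibition, read by MTT assay, with a stated time of 3 days; a lower number here means a stronger inhibitor of growth, a higher number a weaker inhibitor of growth. Two of them are limits rather than numbers: the limit of > 10000 nM in this assay, at which 2 of the 3 values shown sit. Among the compounds with values here, compound 2 holds the only true number, 10000 nM. Compound 4 `Cc1ccc(F)c(NC(=O)Nc2ccc(Nc3ncnc4c3OCCN4)cc2)c1` keeps the shared core and changes one group: 2-fluoro-5-methylphenyl in place of 4-bromophenyl on an amide-type nitrogen. Here 2-fluoro-5-methylphenyl replaces 4-bromophenyl on an amide-type nitrogen. One measured step changes the same place: a number no lower from compound 2 to compound 3 (the limit leaves the size open). From the compounds shown here alone, that step ends at a limit, so its size stays open, and it shows no gain in growth inhibition. No step beyond the scatter is therefore expected in this assay, in either direction. The estimated change is a 1.3-fold lower number from compound 2 to compound 4 (0.10 log units; within the scatter). Compound 4 is expected at 8000 nM, with an estimated range of 1500 nM to 20000 nM.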

Compound 4, concentration for 50% growth inhibition: > 10000 nM
Compound 4 gave a limit, no number; the forecaster's own chance of this, stated with the estimate: 60%; middle value at least 1.2-fold (0.09 log units) from the limit.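

In this assay the change to 2-fluoro-5-methylphenyl gives a number no lower from compound 2 to compound 4 (the limit leaves the size open), so a second replacement of 4-bromophenyl on this amide-type nitrogen, after 3-methoxyphenyl, brings no gain in growth inhibition. The value of compound 4 is a limit, not a number. The step from compound 3 to compound 4 cannot be read, so these replacements cannot be ranked: the limit of > 10000 nM in this assay, at which 3 of the 4 values shown sit.

From the compounds shown here alone, how far compound 3 and compound 4 lie from compound 2 stays open. So does whether an amine or a carboxylic acid on this ring would give a lower number.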